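Swapping amino for fluoro on a shared five-membered core

This account rests on a few compounds, and the source may have more. Where it says the series, first, only, none or still open, it means among the compounds named here.

For the measured compounds named here, the three compounds measured so far share a small heteroaromatic core carrying a substituted phenyl ring. Compound 1 `O=c1nc(-c2ccc(F)cc2)ss1` carries a fluoro group, compound 2 `Nc1ccc(-c2nsc(=O)o2)cc1` an amino group, and compound 3 `COc1cccc(-c2nc(=O)ss2)c1` a methoxy group. In an ADME assay on L02 cells (Homo sapiens) for inhibition, read by MTT assay, with a stated time of 48 h, tested at 100 uM (on this read-out higher numbers stand for more inhibition at the one concentration tested (going by the name of the read-out) and lower numbers for less inhibition), compound 1 gives 33.7%, compound 2 gives 39.5%, and compound 3 gives 38.6%. Compound 2 holds the largest of the three numbers, but its gap to compound 3 and its gap to compound 1 both lie within the usual scatter, so the three compounds cannot be told apart on this read-out.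

Compound 4 `O=c1oc(-c2ccc(F)cc2)ns1` follows from compound 2 by a single exchange: fluoro in place of amino on an aromatic carbon. Going by the values given here, no measured pair with this exchange exists among the three compounds, so no step size can be read off directly. Since the three measured values stand within the scatter of one another, the change is expected to produce no step beyond the scatter in this assay, in either direction. Compound 4 is therefore estimated at 36%, with a range from 25% to 47%. The estimated step of a number 3.5 percentage points lower from compound 2 to compound 4 (within the scatter) is expected to be small.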

Compound 4, a percentage reported as inhibition, at one concentration (the size of the read-out at that concentration, not a potency): 21.7%
For compound 4 the middle estimate is 14.3 percentage points above the measured one; measured number below the stated range.
By their numbers in this assay, from the lowest: compound 4; then compounds 1, 3 and 2 (each within the scatter of the next).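

In this assay, for the compounds shown here, fluoro in place of amino on an aromatic carbon comes with a number 17.8 percentage points lower from compound 2 to compound 4 (beyond the scatter) and so gives the first step in this set that stands clear of the scatter. Going by these compounds alone, this shows that the group at this place, on the six-membered aromatic ring of carbon only and para to a group of 6 heavy atoms, can change the read-out, which the earlier compounds could not show, as no two of them differed in one place and their numbers lay within the scatter of one another. Nothing measured here accounts for the step or ties it to any property of amino or fluoro, so the size of the change stands without an explanation.

The compounds shown leave open whether this single pair reflects something particular to amino or to fluoro, since a hydroxyl, a dimethylamino group or a carboxylic acid at the same place would be needed to separate the two. They also leave open whether the same exchange would bring a step of similar size on the core of compound 1, where fluoro already stands.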